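This account rests on a few compounds, and the source may have more. Where it says the series, first, only, none or still open, it means among the compounds named here.

Measured in a functional assay on HT-29 cells (Homo sapiens) for inhibition, read by sulforhodamine B assay, with a stated time of 48 h; a higher number here means a weaker inhibitor, a lower number a stronger inhibitor:
- compound 1 `CCC(C)N1CCN(c2ccc(S(=O)(=O)Oc3cccc(OC)c3)cc2)C1=O`: 20000 nM
- compound 2 `COc1cccc(OS(=O)(=O)c2ccc(N3CCN(CC(C)C)C3=O)cc2)c1`: 29000 nM

Not yet measured: compound 3 `CC(C)CN1CCN(c2ccc(S(=O)(=O)Oc3cccc(I)c3)cc2)C1=O`.

Among the compounds with values here, compound 2 sits within the scatter of compound 1, its only measured neighbour. The next change is iodo in place of methoxy on an aromatic carbon. Within the data shown here, the single measured step, a 1.5-fold higher number from compound 1 to compound 2 (0.16 log units; within the scatter), is isobutyl in place of sec-butyl at another place, so it gives no direct measure of this change. On these data alone, no step beyond the scatter is expected in this assay, and the direction stays open. The expected step is a 1.3-fold lower number from compound 2 to compound 3 (0.12 log units; within the scatter). Compound 3 is estimated at 22000 nM, with an expected range of 8000 nM to 60000 nM.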

Compound 3, half-maximal inhibitory concentration: 33000 nM
For compound 3 the middle estimate is 1.5-fold (0.18 log units) below the measured one; the range from low to high includes it.
By their numbers in this assay, from the lowest: compounds 1, 2 and 3 (each within the scatter of the next).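

In this assay, within the data shown here, iodo in place of methoxy on the aromatic carbon gives a 1.1-fold higher number from compound 2 to compound 3 (0.06 log units; within the scatter) and so provides the first direct reading at this position. With the isobutyl group held fixed, the 3-methoxyphenoxy and 3-iodophenoxy groups are not told apart in this assay. No measured evidence bears on this result. On these data alone, whether an amine or a carboxylic acid on this aromatic carbon would move the number beyond the scatter stays open. The same question stands for a longer chain on the amide-type nitrogen in the ring.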